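Fluoro for methoxy on the acid-bearing ring

The source may hold more compounds than are shown below. What is called first, only, known or untested is meant among the compounds shown, and "the series" means these compounds.

Two compounds carry a shared core with an acid-bearing aromatic ring, and both have numbers in an assay for positive allosteric modulation of metabotropic glutamate receptor 2 (Rattus norvegicus); a lower number here means that less compound is needed, a higher number that more compound is needed for the effect. Compound 1, `Cc1c(OC[C@@H](C)COc2ccc(Cl)c(C(=O)O)c2)ccc(C(=O)CC(C)(C)C)c1O`, gives 377 nM. Compound 2, `COc1cc(C(=O)O)ccc1OC[C@H](C)COc1ccc(C(=O)CC(C)(C)C)c(O)c1C`, gives 28 nM. Compound 2 thus stands at the lowest of the two numbers; its nearest neighbour, compound 1, is a clearly higher number, and the gap between the two lies beyond the scatter.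

Compound 3, `Cc1c(OC[C@@H](C)COc2ccc(C(=O)O)cc2F)ccc(C(=O)CC(C)(C)C)c1O`, has not yet been measured in this assay. It differs from compound 2 in one place: fluoro in place of methoxy on an aromatic carbon. No step between two measured compounds isolates this change, so the expectation must rest on the two numbers shown alone. Compound 2, with its 28 nM, is the closer starting point, and a change of a single group on its acid-bearing ring is expected to move the number by a modest step upward, a 2.9-fold higher number from compound 2 to compound 3 (0.46 log units; beyond the scatter), beyond the scatter but well short of the distance to compound 1. For compound 3 the estimate in this assay is therefore 80 nM, within a range from 25 nM to 250 nM.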

Compound 3, half-maximal effective concentration: 222 nM
The estimate for compound 3 lay 2.8-fold (0.44 log units) below the measured number; low and high end bracket the measured number.
By their numbers in this assay, from the lowest: compound 2; then compounds 3 and 1 (each within the scatter of the next).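

In this assay, the carbon ortho to a large group and meta to a carboxy group proves sensitive to what it carries: fluoro in place of methoxy gives a 7.9-fold higher number from compound 2 to compound 3 (0.90 log units; beyond the scatter), so this one exchange accounts for a large share of the distance that the first two compounds had shown only as an unexplained gap between different acid-bearing rings. The second step, a 1.7-fold lower number from compound 1 to compound 3 (0.23 log units; within the scatter), lies within the scatter, so the 4-carboxy-2-fluorophenyl group of compound 3 cannot be told apart from the 3-carboxy-4-chlorophenyl group of compound 1, and the low number of compound 2 now stands alone among the three. Nothing measured here accounts for the size of the step from methoxy to fluoro.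

The compounds shown leave open whether the low number of compound 2 belongs to methoxy in particular, since ethoxy, hydroxy or a plain hydrogen on that carbon would separate the presence of an oxygen there from the size of the group. They also leave open whether the same exchange would give a step of similar size on a ring with the carboxy group placed as in compound 1.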